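Changing the aryl end of compound 1 to give compound 4

A few compounds are considered here, and "the series" means these few. Any claim that something is new, unique, unknown or untested is made for them only; others in the source may bear on it.

Measured so far in a functional assay on MDA-MB-231 cells (Homo sapiens) for cytotoxicity, read by MTT assay, with a stated time of 48 h; a lower number here means a stronger inhibitor, a higher number a weaker inhibitor:
compound 1, `CNC(=O)c1cc(Oc2cccc(NC(=S)Nc3ccc(Cl)cc3)c2)ccn1`, > 100000 nM
compound 2, `CC(C)NC(=O)c1cc(Oc2cccc(NC(=S)Nc3ccc(Cl)cc3)c2)ccn1`, 87500 nM
compound 3, `O=C(NCc1ccccc1)c1cc(Oc2cccc(NC(=S)Nc3ccc(Cl)cc3)c2)ccn1`, > 100000 nM

The value of compound 1 is a limit of the assay, not a number. Compound 2 gives a measured number, while the value of compound 3 is again a limit. Compound 1 thus stands at the limit of > 100000 nM in this assay, at which 2 of the 3 values shown sit, at the weak end of what has been seen.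

The measured steps all alter the group on the amide-type nitrogen at the other end of the shared core: an at least 1.1-fold lower number from compound 1 to compound 2 (0.05 log units; that floor lies within the scatter), an at least 1.1-fold higher number from compound 2 to compound 3 (0.05 log units; that floor lies within the scatter), and a step that the two limits leave unreadable from compound 1 to compound 3. None of them touches the aryl group bound to the nitrogen next to the thiocarbonyl carbon.

Compound 4, `CNC(=O)c1cc(Oc2cccc(NC(=S)Nc3cccc(C(F)(F)F)c3)c2)ccn1`, differs from compound 1 exactly there: 3-(trifluoromethyl)phenyl in place of 4-chlorophenyl on an amide-type nitrogen. Within the data shown here, no measured step bears on this change, so there is no basis to expect a step beyond the scatter in this assay in either direction. Compound 4 is therefore expected to sit around 100000 nM, somewhere between 30000 nM and 300000 nM. That estimate amounts to an expected a number no higher from compound 1 to compound 4 (the limit leaves the size open).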

Compound 4, half-maximal inhibitory concentration: > 100000 nM
Compound 4 ended at the assay's limit; the forecaster's own chance of this, stated with the estimate: 65%; the middle value lies on the limit itself.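

Compound 1 and compound 4 both end at a limit of the assay rather than at a number, so no step between them can be read in this assay: the limit of > 100000 nM in this assay, at which 3 of the 4 values shown sit.

The compounds shown leave open whether 3-(trifluoromethyl)phenyl in place of 4-chlorophenyl changes cytotoxicity at all.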